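Amide tail variation on the shared core

This account rests on a few compounds, and the source may have more. Where it says the series, first, only, none or still open, it means among the compounds named here.

Compound 1 `CCn1c(C(=O)NCCO)ccc1C(CC)(CC)c1ccc(OCS(=O)(=O)c2ccccc2)c(C)c1` carries a 2-hydroxyethyl group on the amide nitrogen, and in a functional assay on BXPC-3 cells (Homo sapiens) for antiproliferative activity, read by MTT assay, with a stated time of 24 h (a lower number here means a stronger inhibitor, a higher number a weaker inhibitor), compound 1 gives 19900 nM. Of the two plain numbers recorded, compound 1 has the highest; its nearest neighbour is compound 2 `CCn1c(C(=O)N[C@@H](CO)CCCO)ccc1C(CC)(CC)c1ccc(OCS(=O)(=O)c2ccccc2)c(C)c1`, which in this assay gives 16400 nM, a gap of a 1.2-fold lower number from compound 1 to compound 2 (0.08 log units; within the scatter), so the two cannot be ordered. Compound 3 `CCn1c(C(=O)NCCC(=O)O)ccc1C(CC)(CC)c1ccc(OCS(=O)(=O)c2ccccc2)c(C)c1` reaches only the limit of this assay and is recorded as > 50000 nM. That amounts to a step of an at least 2.5-fold higher number from compound 1 to compound 3 (0.40 log units; beyond the scatter), the carboxy in place of hydroxy leaving a weaker inhibitor; the same is seen in an at least 3.0-fold higher number from compound 2 to compound 3 (0.48 log units; beyond the scatter).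

Compound 4 `CCn1c(C(=O)N[C@H](CCC(=O)O)C(=O)O)ccc1C(CC)(CC)c1ccc(OCS(=O)(=O)c2ccccc2)c(C)c1` is not yet measured. Its change from compound 1 is 1,3-dicarboxypropyl in place of 2-hydroxyethyl on an amide-type nitrogen. The step that bears on it most directly is the carboxy-for-hydroxy change, an at least 2.5-fold higher number from compound 1 to compound 3 (0.40 log units; beyond the scatter), which carried compound 3 onto the limit (the limit of > 50000 nM in this assay, at which 1 of the 3 values shown sits). Compound 4 brings carboxy groups in with the 1,3-dicarboxypropyl group, so a step of similar or larger size toward a weaker inhibitor is expected, quite possibly past the limit again. For compound 4 in this assay the expected value is 60000 nM, in the range 25000 nM to 150000 nM, which corresponds to an expected step of a 3.0-fold higher number from compound 1 to compound 4 (0.48 log units; beyond the scatter).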

Compound 4, half-maximal inhibitory concentration: > 50000 nM
Compound 4: no number, only a limit (the forecaster's own chance of this, stated with the estimate: 70%); the middle value lies beyond the limit too.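

The 1,3-dicarboxypropyl group on the amide-type nitrogen leaves compound 4 with only a limit in this assay, so a larger carboxy-bearing tail with a defined stereocentre ends in the same place as the 2-carboxyethyl tail of compound 3: the limit of > 50000 nM in this assay, at which 2 of the 4 values shown sit.

Measured against the two hydroxy-bearing tails, the change gives an at least 2.5-fold higher number from compound 1 to compound 4 (0.40 log units; beyond the scatter) and an at least 3.0-fold higher number from compound 2 to compound 4 (0.48 log units; beyond the scatter). Across the four compounds shown, the hydroxy-bearing tails of compound 1 and compound 2 give numbers and the carboxy-bearing tails of compound 3 and compound 4 give only limits, and no compound shown goes against this split.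

On these data alone, the step from compound 3 to compound 4 cannot be read, so whether the 1,3-dicarboxypropyl group costs more than the 2-carboxyethyl group remains unknown. Also open, as far as these compounds go, is whether a methyl ester or a primary carboxamide in place of the carboxy groups, or a primary amine at the end of the chain, would bring a tail back to a plain number in this assay.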